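A few compounds are considered here, and "the series" means these few. Any claim that something is new, unique, unknown or untested is made for them only; others in the source may bear on it.

Measured compounds:
compound 1 `COc1cccc(-c2nc(SC)nc3sc(C(=O)N(C)C(C)(C)C)c(N)c23)c1`, a functional assay on HEK293 cells for agonist activity at lutropin-choriogonadotropic hormone receptor (Homo sapiens), read by cAMP accumulation; a lower number here means that less compound is needed, a higher number that more compound is needed for the effect: 800 nM
compound 2 `COc1cccc(-c2nc(SC)nc3sc(C(=O)NNC(C)(C)C)c(N)c23)c1`, this assay: "not determined" (no result reported)
compound 3 `CCNC(=O)c1sc2nc(SC)nc(-c3cccc(OC)c3)c2c1N`, this assay: "not determined" (no result reported)

Compound 3 stands without a number in this assay; its result was not determined, and compound 2 likewise carries no result. The only figure available on the shared core is that of compound 1, which in this assay gives 800 nM. Compound 4 `COc1cccc(-c2nc(SC)nc3sc(C(=O)OC(C)(C)C)c(N)c23)c1` arises from compound 3 by tert-butoxy in place of ethylamino on a carbonyl carbon. For the measured compounds named here, with no measured step between two compounds to lean on, and compound 3 itself unquantified, no direction of change can be read from the data; the expectation rests on compound 1 alone. Compound 4 is therefore estimated to give about 1200 nM, expected to lie between 250 nM and 6000 nM.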

Compound 4, half-maximal effective concentration: 1100 nM
The estimate for compound 4 lay 1.1-fold (0.04 log units) above the measured number; the range from low to high includes it.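

In this assay, for the compounds shown here, the first measured step at this carbonyl carbon, with tert-butoxy in place of methyl(tert-butyl)amino, gives a 1.4-fold higher number from compound 1 to compound 4 (0.14 log units; within the scatter), so the two groups cannot be told apart here. Both compounds therefore hold a number on the shared core, with either nitrogen or oxygen attached to the carbonyl carbon. No data at hand bear on why the two groups read alike.

On these data alone, the steps from compound 2 and compound 3 cannot be read, so the effect of ethylamino remains unknown. As far as these compounds go, how a carboxylic acid or a longer chain at this carbonyl carbon would read also stays open.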